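This account rests on a few compounds, and the source may have more. Where it says the series, first, only, none or still open, it means among the compounds named here.

Compound 2 (`COc1cc(-n2cnc3ccc(-c4cccc(C)c4C)cc32)cc(OC)c1OC`) sits at the weak end of the two results so far. In a functional assay on SGC-7901 cells (Homo sapiens) for antiproliferative activity, read by MTT assay, with a stated time of 72 h (on this read-out lower numbers stand for stronger inhibition and higher numbers for weaker inhibition), compound 2 gives 3040 nM, the higher of the two numbers, while compound 1 (`COc1cc(-n2cnc3ccc(-c4ccc(C(C)=O)cc4)cc32)cc(OC)c1OC`) gives 450 nM. The next structure is compound 3 (`COc1cc(-n2cnc3ccc(-c4ccc(C)cc4)cc32)cc(OC)c1OC`), which keeps the shared core and has 4-methylphenyl in place of 2,3-dimethylphenyl on an aromatic carbon.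

Within the data shown here, only one measured step bears on this change: a 6.8-fold higher number from compound 1 to compound 2 (0.83 log units; beyond the scatter), where 2,3-dimethylphenyl replaced 4-acetylphenyl at the same place. That step is modest but beyond the scatter. Among the measured compounds shown here, it is also a single comparison, so it shows no trend, and no measured compound carries 4-methylphenyl. By name, the entering group is closer to the 4-acetylphenyl of compound 1, at 450 nM, than to the group it replaces. Part of that gap is therefore expected to be recovered in this assay, with the number falling but probably not all the way to that of compound 1. The expected move is a 3.4-fold lower number from compound 2 to compound 3 (0.53 log units; beyond the scatter). The estimated value of compound 3 is 900 nM, with an expected range from 300 nM to 2500 nM.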

Compound 3, half-maximal inhibitory concentration: 200 nM
Compound 3: the middle estimate sits 4.5-fold (0.65 log units) above what was measured, and the stated range ends above it.
By their numbers in this assay, from the lowest: compound 3; then compound 1; then compound 2.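

In this assay, among these compounds, the change from 2,3-dimethylphenyl to 4-methylphenyl gives a 15-fold lower number from compound 2 to compound 3 (1.18 log units; beyond the scatter), the largest step seen so far, so this position responds strongly to a change of only one methyl group and its placement on the phenyl ring. Among the compounds shown here, the acetyl of compound 1 is also not required for a low number, as methyl in place of acetyl gives a 2.3-fold lower number from compound 1 to compound 3 (0.35 log units; beyond the scatter), and among the three compounds the two phenyl groups carrying one group at the 4-position both read lower than the 2,3-dimethylphenyl of compound 2, with no compound going against this. No measurement on hand explains either step.

Compound 2 and compound 3 differ in both the number and the placement of their methyl groups, so the share of each methyl group in the step between them remains unresolved. As far as these compounds go, it also remains open whether the trend from acetyl to methyl continues, and how a plain phenyl, or an amine or a carboxylic acid in place of the methyl of compound 3, would read in this assay.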